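Diiodophenol hydrazones: cytotoxicity notes toward compound 3

The source may hold more compounds than are shown below. What is called first, only, known or untested is meant among the compounds shown, and "the series" means these compounds.

Measured compounds:
compound 1 `O=C(N/N=C/c1cc(I)cc(I)c1O)c1ccc([N+](=O)[O-])cc1` — 24700 nM
compound 2 `Cc1ccc(C(=O)N/N=C/c2cc(I)c(O)c(I)c2)cc1` — > 100000 nM

In a functional assay on HepG2 cells (Homo sapiens) for cytotoxicity, with a stated time of 24 h (a higher number here means a weaker inhibitor, a lower number a stronger inhibitor), compound 1 gives 24700 nM. For compound 2 this assay reports a limit only, > 100000 nM, not a number; this is the limit of > 100000 nM in this assay, at which 1 of the 2 values shown sits. Going by the values given here, compound 1 and compound 2 differ in more than one place, so no step is drawn between them; their values show only that compound 1 gives a number while compound 2 does not.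

Compound 3 `O=C(N/N=C/c1cc(I)c(O)c(I)c1)c1ccc(Br)cc1` is compound 2 with bromo in place of methyl on an aromatic carbon, para to a large group. Among the compounds with values here, no measured step covers this change, so the expected size rests on the limit of compound 2 alone; no shift beyond the usual scatter is expected in this assay, and a limit is again likely. Compound 3 is estimated at 90000 nM, within 25000 nM to 300000 nM, the expected step being an at least 1.1-fold lower number from compound 2 to compound 3 (0.04 log units; that floor lies within the scatter).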

Compound 3, half-maximal inhibitory concentration: > 50000 nM
Compound 3 gave a limit, no number (the forecaster's own chance of this, stated with the estimate: 60%); the middle value is on the limit's open side.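

No step can be read between compound 2 and compound 3 in this assay: each gives a limit and no number. The compounds shown leave open whether bromo in place of methyl on an aromatic carbon changes the read-out at all, and where the actual values of compound 2 and compound 3 lie.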